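Benzyl for Chlorophenyl on the Alkyne Arm

The source may hold more compounds than are shown below. What is called first, only, known or untested is meant among the compounds shown, and "the series" means these compounds.

Going by the values given here, compound 2 (`Cn1c(=O)c2c(cc(C#Cc3cccc(Cl)c3)n2C)n(C)c1=O`) gives 173 nM in an assay on isolated protein for inhibition of Amine oxidase [flavin-containing] B (Homo sapiens), read by luminescence, with a stated time of 1 h (a higher number here means a weaker inhibitor, a lower number a stronger inhibitor), and this is the only number among the values shown. Compound 1 (`Cn1c(=O)c2c(cc(/C=C/c3cccc(C#N)c3)n2C)n(C)c1=O`) reaches only a limit in this assay, namely > 10000 nM. That limit is the limit of > 10000 nM in this assay, at which 1 of the 2 values shown sits. Compound 3 (`Cn1c(=O)c2c(cc(C#CCc3ccccc3)n2C)n(C)c1=O`) differs from compound 2 by benzyl in place of 3-chlorophenyl on a triple-bonded carbon. Among the compounds with values here, no measured pair shows this exchange, so its size is open; a loss beyond the usual scatter in this assay seems the likelier direction. Compound 3 is therefore estimated at 2000 nM, within 500 nM to 10000 nM. That estimate means an expected 12-fold higher number from compound 2 to compound 3 (1.06 log units; beyond the scatter) in this assay.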

Compound 3, half-maximal inhibitory concentration: > 1000 nM
Compound 3 ended at the assay's limit; the forecaster's own chance of this, stated with the estimate: 25%; the middle value does not contradict the limit.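

On the triple-bonded carbon, benzyl in place of 3-chlorophenyl weakens inhibition in this assay, with an at least 5.7-fold higher number from compound 2 to compound 3 (0.76 log units; beyond the scatter). Both groups hold one six-membered aromatic ring of carbon only and the same count of heavy atoms, so that ring alone does not preserve the inhibition seen with 3-chlorophenyl. Compound 3 reaches only a limit, not a number: the limit of > 1000 nM in this assay, at which 1 of the 3 values shown sits.

The exchange removes the chlorine and adds a carbon link at once, and the compounds shown do not separate the two. Going by these compounds, how an unsubstituted phenyl, an amine or a longer chain would fare on this carbon remains open.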